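Bromo in Place of Iodo: What the Cell Assay May Show

The source may report more compounds than this note shows. Statements on the series, on what has been measured and on what is new or still open speak of the compounds shown alone.

Among the measured compounds shown here, compound 3 `COc1cc(NC(=O)Nc2cc(Nc3cc(I)ccc3OC)ncn2)cc(OC)c1` gives 71% in a functional assay on HCC827 cells (Homo sapiens) for inhibition, read by MTT assay, with a stated time of 48 h, tested at 10 uM (a higher number here means more inhibition at the concentration tested (going by the name of the read-out), a lower number less inhibition), the highest of the three numbers measured so far. Compound 1 `COc1cc(NC(=O)Nc2cc(Nc3ccc(F)c(Cl)c3)ncn2)cc(OC)c1` gives 53.1%, and compound 2 `COc1ccc(Br)cc1Nc1cc(NC(=O)Nc2c(Cl)cccc2Cl)ncn1` gives 53%; both stand below compound 3 beyond the scatter. For the measured compounds named here, the only single-place step measured is a number 17.9 percentage points higher from compound 1 to compound 3 (beyond the scatter), and it concerns a different part of the molecule. Compound 4 `COc1cc(NC(=O)Nc2cc(Nc3cc(Br)ccc3OC)ncn2)cc(OC)c1` differs from compound 3 by bromo in place of iodo on an aromatic carbon. Going by the values given here, no measured step bears directly on swapping one halogen for another, and the change keeps the same count of heavy atoms, donors and acceptors. The step of a number 5 percentage points lower from compound 3 to compound 4 (within the scatter) is therefore expected to be small, without a clear direction, and likely within the scatter. Compound 4 is expected to give about 66%, in the range 54% to 78%.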

Compound 4, a percentage reported as inhibition, at one concentration (the size of the read-out at that concentration, not a potency): 76.3%
The estimate for compound 4 lay 10.3 percentage points below the measured number; low and high end bracket the measured number.
By their numbers in this assay, from the lowest: compounds 2 and 1 (each within the scatter of the next); then compounds 3 and 4 (each within the scatter of the next).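

At this position, para to a methoxy group, bromo in place of iodo gives a number 5.3 percentage points higher from compound 3 to compound 4 (within the scatter) in this assay and so leaves the two halogens indistinguishable here. The 5-bromo-2-methoxyphenyl group in place of 3-chloro-4-fluorophenyl gives a number 23.2 percentage points higher from compound 1 to compound 4 (beyond the scatter) and 3,5-dimethoxyphenyl in place of 2,6-dichlorophenyl on the amide-type nitrogen gives a number 23.3 percentage points higher from compound 2 to compound 4 (beyond the scatter) as a second single-place step from the bromo compound. Nothing available explains any of these steps.

The compounds shown leave open whether chloro, an amine or a carboxylic acid at this position would keep the number in this range. They also leave open what the methoxy group contributes.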